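Swapping the ring on the amide nitrogen of compound 1

The source may hold more compounds than are shown below. What is called first, only, known or untested is meant among the compounds shown, and "the series" means these compounds.

Compound 1 `Cc1ccc(OCC(=O)N(Cc2cccs2)c2ccn(C)n2)cc1` is the strongest of the three measured compounds in an assay on HEK293 cells for agonist activity at transient receptor potential cation channel subfamily M member 8 (Homo sapiens), read by fluorescence and calcium flux, with a stated time of 15 min (on this read-out lower numbers stand for an effect already at smaller amounts and higher numbers for an effect only at larger amounts of compound), where compound 1 gives 855 nM. Compound 2 `CCN(Cc1cccnc1)C(=O)COc1ccc(C)cc1` gives 15400 nM and compound 3 `CCN(Cc1cc[nH]c1)C(=O)COc1ccc(C)cc1` gives 21800 nM, so both stand far behind compound 1. Compound 4 `Cc1ccc(OCC(=O)N(Cc2cccs2)c2ccccn2)cc1` differs from compound 1 by one change: pyridin-2-yl in place of 1-methyl-1H-pyrazol-3-yl on an amide-type nitrogen. For the measured compounds named here, the single measured step, a 1.4-fold higher number from compound 2 to compound 3 (0.15 log units; within the scatter), concerns a ring on a saturated chain carbon, not on the amide nitrogen, so no measured step bears directly on this change. Compound 4 is therefore expected to stay near compound 1, with a step of a 1.4-fold higher number from compound 1 to compound 4 (0.15 log units; within the scatter), and its estimated value is 1200 nM, between 300 nM and 5000 nM.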

Compound 4, half-maximal effective concentration: 200 nM
Estimate against measurement, compound 4: 6.0-fold (0.78 log units) above; the measured number lies below the stated range.
By their numbers in this assay, from the lowest: compound 4; then compound 1; then compounds 2 and 3 (each within the scatter of the next).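

At this position, on an amide-type nitrogen, the ring does affect the read-out: in this assay, pyridin-2-yl in place of 1-methyl-1H-pyrazol-3-yl gives a 4.3-fold lower number from compound 1 to compound 4 (0.63 log units; beyond the scatter). The two rings have equal heavy-atom counts, so this step comes with a change in ring size and hetero atoms, not in the number of heavy atoms. Nothing available explains the drop in the number. As far as these compounds go, whether a plain phenyl ring or a pyrimidin-2-yl ring on the same nitrogen would give a lower or higher number remains open. So does whether an amine on the pyridin-2-yl ring would be tolerated.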